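Dimethylamino in Place of Hydroxy: What to Expect

This account rests on a few compounds, and the source may have more. Where it says the series, first, only, none or still open, it means among the compounds named here.

Compound 1 `C(=N/N(Cc1ccccc1)Cc1ccccc1)\c1ccccc1` and compound 2 `Oc1ccc(/C=N/N(Cc2ccccc2)Cc2ccccc2)cc1` share one core. In an assay on liver (Sus scrofa) for inhibition of glucose-6-phosphatase catalytic subunit 1 (Homo sapiens), using microsomes (a lower number here means a stronger inhibitor, a higher number a weaker inhibitor), compound 1 gives 1500 nM and compound 2 gives 2400 nM; compound 2 stands alongside compound 1, and the step of a 1.6-fold higher number from compound 1 to compound 2 (0.20 log units; within the scatter) is within the scatter, so the two cannot be separated. Compound 3 `CN(C)c1ccc(/C=N/N(Cc2ccccc2)Cc2ccccc2)cc1` carries dimethylamino in place of hydroxy on an aromatic carbon, placed on an aromatic carbon of a six-membered aromatic ring of carbon only, para to a large group. Among the measured compounds shown here, the only measured step, at the same place, stayed within the scatter, so no change beyond the scatter is expected here. Compound 3 is estimated at 2000 nM, between 700 nM and 6000 nM, an expected step of a 1.2-fold lower number from compound 2 to compound 3 (0.08 log units; within the scatter).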

Compound 3, half-maximal inhibitory concentration: 100000 nM
Estimate against measurement, compound 3: 50-fold (1.70 log units) below; the measured number lies above the stated range.
By their numbers in this assay, from the lowest: compounds 1 and 2 (each within the scatter of the next); then compound 3.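

On the aromatic carbon para to a large group, hydrogen and hydroxy could not be separated, but this position does not accept every group: dimethylamino gives a 42-fold higher number from compound 2 to compound 3 (1.62 log units; beyond the scatter), and measured against hydrogen it gives a 67-fold higher number from compound 1 to compound 3 (1.82 log units; beyond the scatter). The position is therefore sensitive to what it carries, and a within-scatter first step did not predict the next. Nothing available explains this large rise.

As far as these compounds go, whether methoxy or a single methylamino group would track hydroxy or dimethylamino remains open. So does whether the added heavy atoms or the lost hydrogen-bond donor matters more.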